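The source may hold more compounds than are shown below. What is called first, only, known or untested is meant among the compounds shown, and "the series" means these compounds.

Measured so far:
Compound 1 `O=C(O)c1ccc(C(=O)/C(=C\c2ccc(F)c([N+](=O)[O-])c2)Sc2ccc(Br)cc2)cc1`: < 1000 ug/mL
Compound 2 `O=C(O)c1ccc(C(=O)/C(=C\c2ccc(F)c([N+](=O)[O-])c2)SCc2ccccc2)cc1`: < 1000 ug/mL

Both values come from a physicochemical assay for solubility; on this read-out higher numbers stand for higher solubility and lower numbers for lower solubility. Compound 2 stands at < 1000 ug/mL, which is a limit of the assay and not a number. Compound 1 gives < 1000 ug/mL, and this is also a limit. The whole picture so far is the limit of < 1000 ug/mL in this assay, at which 2 of the 2 values shown sit.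

Compound 3 `O=C(O)c1ccc(C(=O)/C(=C\c2ccc(F)c([N+](=O)[O-])c2)[S+]([O-])Cc2ccc(Br)cc2)cc1` is the next to be measured, and it differs from compound 2 as follows: a group of 10 heavy atoms (7 carbon, 1 oxygen, 1 sulfur, 1 bromine; one six-membered aromatic ring of carbon only) in place of a group of 8 heavy atoms (7 carbon, 1 sulfur; one six-membered aromatic ring of carbon only), on a double-bonded chain carbon bound to a carbonyl carbon and a double-bonded chain carbon.

For the measured compounds named here, the only measured step that bears on this change is a step that the two limits leave unreadable from compound 1 to compound 2. It offers no size and no direction to carry over, so no step beyond the scatter is expected in this assay. The expected step is a step that the limit leaves unreadable from compound 2 to compound 3. Compound 3 may also be reported only as a limit. For compound 3 the estimated value is 600 ug/mL, with an expected range from 200 ug/mL to 1000 ug/mL.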

Compound 3, solubility: < 1000 ug/mL
Compound 3 gave a limit, no number (the forecaster's own chance of this, stated with the estimate: 80%); the middle value lies beyond the limit too.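

In this assay compound 3 gives < 1000 ug/mL, which is a limit and not a number. No step among compound 1, compound 2 and compound 3 can be read, and the picture remains: the limit of < 1000 ug/mL in this assay, at which 3 of the 3 values shown sit.

What the compounds shown leave open is where each of the three truly stands in this assay, and whether their differing groups shift the read-out at all.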